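Phenyl in place of 2-aminoethyl: notes on compound 3

The source may report more compounds than this note shows. Statements on the series, on what has been measured and on what is new or still open speak of the compounds shown alone.

In a functional assay on HCT-116 cells (Homo sapiens) for antiproliferative activity, read by MTT assay (on this read-out lower numbers stand for stronger inhibition and higher numbers for weaker inhibition), compound 1 (`O=C1C=C(NCCO)C(=O)c2ccccc21`) gives 70300 nM and compound 2 (`NCCCNC1=CC(=O)c2ccccc2C1=O`) gives 59600 nM. Compound 2 therefore stands level with compound 1, and the two cannot be ranked. Compound 3 (`O=C1C=C(NCc2ccccc2)C(=O)c2ccccc21`) has phenyl in place of 2-aminoethyl on a saturated chain carbon bound to an amine nitrogen. Among the compounds with values here, only one measured step bears on this change: a 1.2-fold lower number from compound 1 to compound 2 (0.07 log units; within the scatter), which lies within the scatter. Within the data shown here, that step exchanges aminomethyl for hydroxy, and no measured compound carries a ring on the chain, so the data give little guidance on direction. A modest move towards a lower number is tentatively expected, and no change at all remains possible. The expected step is a 2.0-fold lower number from compound 2 to compound 3 (0.30 log units; within the scatter). For compound 3 the estimated value is 30000 nM, with an expected range of 10000 nM to 80000 nM.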

Compound 3, half-maximal inhibitory concentration: 130000 nM
Compound 3: middle estimate off by 4.3-fold (0.64 log units), on the low side; measured number outside the range, above it.
By their numbers in this assay, from the lowest: compounds 2, 1 and 3 (each within the scatter of the next, the first and the last beyond it).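

In this assay, within the data shown here, the step of a 2.2-fold higher number from compound 2 to compound 3 (0.34 log units; beyond the scatter) is the first on this chain to lie beyond the scatter; it is modest, and it runs towards weaker inhibition, so phenyl on the saturated chain carbon bound to an amine nitrogen brings no gain over 2-aminoethyl. Set against the hydroxy-ended chain, the step of a 1.8-fold higher number from compound 1 to compound 3 (0.27 log units; within the scatter) stays within the scatter, so compound 1 and compound 3 cannot be ranked, and the phenyl compound separates clearly only from compound 2. Nothing available on measured properties accounts for the difference between compound 2 and compound 3.

Open, going by these compounds, is whether a longer chain carrying the phenyl ring, such as 2-phenylethyl, would stand closer to compound 2 or to compound 3. Also open, on these data alone, is how a phenyl ring bearing a methoxy group or a chlorine atom, or a chain ending in a dimethylamino group, would compare with these compounds.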